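A few compounds are considered here, and "the series" means these few. Any claim that something is new, unique, unknown or untested is made for them only; others in the source may bear on it.

Measured so far in a functional assay on PC-9 cells (Homo sapiens) for inhibition, read by MTT assay, with a stated time of 72 h; a higher number here means a weaker inhibitor, a lower number a stronger inhibitor:
compound 1, `Cc1cc(Nc2cc(-c3ccccc3)[nH]n2)n2ncnc2n1`, gives > 50000 nM, which is a limit of the assay and not a number.
compound 2, `Cc1cc(Nc2cc(-c3ccccc3)[nH]n2)n2nc(SCc3csc4ccccc34)nc2n1`, gives 4420 nM.
compound 3, `Cc1cc(Nc2cc(-c3ccccc3)[nH]n2)n2nc(SCc3ccc(Br)cc3)nc2n1`, gives 4760 nM.

Compound 3 thus holds the higher of the two numbers, with compound 2 nearest at a gap within the scatter. The step to compound 4, `Cc1cc(Nc2cc(-c3ccccc3)[nH]n2)n2nc(SCC3CC3)nc2n1`, is cyclopropyl in place of 4-bromophenyl on a saturated chain carbon bound to a sulfur. Within the data shown here, two measured steps bear on it: an at least 11-fold lower number from compound 1 to compound 2 (1.05 log units; beyond the scatter) and an at least 10-fold lower number from compound 1 to compound 3 (1.02 log units; beyond the scatter), both large, showing that the sulfanyl substituent itself carries the gain. The exchange within that substituent, a 1.1-fold higher number from compound 2 to compound 3 (0.03 log units; within the scatter), was within the scatter. Compound 4 keeps the substituent but with a three-membered ring in place of the six-membered aromatic ring, so a modest weakening is expected: a 1.9-fold higher number from compound 3 to compound 4 (0.28 log units; within the scatter). Compound 4 is therefore estimated at 9000 nM, between 3000 nM and 30000 nM.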

Compound 4, half-maximal inhibitory concentration: > 50000 nM
Compound 4: a limit, no number; the forecaster's own chance of this, stated with the estimate: 15%; middle value at least 5.5-fold (0.74 log units) away from the limit.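

The group on the saturated chain carbon bound to a sulfur proves decisive, with an at least 10-fold higher number from compound 3 to compound 4 (1.02 log units; beyond the scatter) and an at least 11-fold higher number from compound 2 to compound 4 (1.05 log units; beyond the scatter). The sulfanyl link alone therefore does not bring the gain, although 4-bromophenyl and 1-benzothiophen-3-yl could not be told apart at that place. In this assay compound 4 sits at a limit and not a number, as does compound 1, so the step between them cannot be read: the limit of > 50000 nM in this assay, at which 2 of the 4 values shown sit.

On these data alone, whether a cyclohexyl group or a longer chain on that carbon would keep the gain stays open, as does the outcome with an amine there.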